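Butoxy in place of benzyl: an expected growth-inhibition value

The compounds below may be only part of what the source reports. "The series", "measured", "known", "first", "only" and "open" are said of these compounds alone.

Measured compounds:
Compound 1 `O=C(Nc1ccccc1OC(F)(F)F)Nc1n[nH]c2ccccc12` gives 26100 nM in a functional assay on NCI-H226 cells (Homo sapiens) for inhibition, read by sulforhodamine B assay, with a stated time of 48 h; on this read-out lower numbers stand for stronger inhibition of growth and higher numbers for weaker inhibition of growth.
Compound 2 `Nc1nn(C(=O)Nc2ccc(Cc3ccccc3)cc2)c2ccccc12` gives 13500 nM in this assay.
Compound 3 `COc1ccc(NC(=O)Nc2n[nH]c3ccccc23)cc1` gives > 100000 nM in this assay, which is a limit of the assay rather than a number.

Among the two numbers, compound 2 has the lower one, but compound 1 sits within the usual scatter of it, so no order between the two can be read. Compound 4 `CCCCOc1ccc(NC(=O)n2nc(N)c3ccccc32)cc1` shares the core of compound 2 and differs in one place: butoxy in place of benzyl on an aromatic carbon. Among the measured compounds shown here, no measured pair shows this change, so the size of the step in this assay is open; a modest move toward weaker inhibition, possibly none beyond the scatter, is expected. Compound 4 is estimated at 25000 nM, between 8000 nM and 100000 nM, which means an expected step of a 1.9-fold higher number from compound 2 to compound 4 (0.27 log units; within the scatter).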

Compound 4, concentration for 50% growth inhibition: 21200 nM
For compound 4 the middle estimate is 1.2-fold (0.07 log units) above the measured one; the range from low to high includes it.
By their numbers in this assay, from the lowest: compounds 2, 4 and 1 (each within the scatter of the next). At a limit, above all of these: compound 3.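

In this assay, butoxy in place of benzyl on an aromatic carbon gives a 1.6-fold higher number from compound 2 to compound 4 (0.20 log units; within the scatter), so this single pair shows that a chain with no ring and an oxygen can stand at this position with no readable difference from the ringed group. Compound 3 alone sits at a limit of the assay, not a number, and neither member of this pair reaches it: the limit of > 100000 nM in this assay, at which 1 of the 4 values shown sits.

On these data alone, whether any group at this position can separate from these two stays open. An amine or a carboxylic acid on the same aromatic carbon would be one test of that.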